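A few compounds are considered here, and "the series" means these few. Any claim that something is new, unique, unknown or untested is made for them only; others in the source may bear on it.

Working notes on the series in a physicochemical assay for solubility, with a stated time of 18 h, at pH 7.4; a higher number here means a more soluble compound, a lower number a less soluble compound.

Compound 1 `COc1cccc(Oc2ccc3c(NCCCNCc4cccc(OC)c4O)ccnc3c2)c1` gives 14500 nM. Compound 2 `COc1cccc(CNCCCNc2ccnc3cc(Cc4ccc(C#N)cc4)ccc23)c1O` gives 4200 nM, and compound 3 `COc1cccc(CNCCCNc2ccnc3cc(CC4CCCCC4)ccc23)c1O` gives 4200 nM. Compound 2 thus stands level with compound 3 at the digits printed, the two together the lowest of the three numbers; its furthest neighbour is compound 1, a 3.5-fold lower number from compound 1 to compound 2 (0.54 log units; beyond the scatter). The matching change a 3.5-fold lower number from compound 1 to compound 3 (0.54 log units; beyond the scatter) is of the same size, and no change at the digits printed from compound 2 to compound 3 (within the scatter).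

Compound 4 `N#Cc1ccc(Cc2ccc3c(NCCCNCc4ccco4)ccnc3c2)cc1` differs from compound 2 by furan-2-yl in place of 2-hydroxy-3-methoxyphenyl on a saturated chain carbon bound to an amine nitrogen. Going by the values given here, none of the measured steps bears on this change: all three alter the substituent on the aromatic carbon of the shared core, whereas the change to compound 4 sits on the saturated chain carbon bound to the amine nitrogen, the benzylamine end, which is held constant in compounds 1 to 3. Among the compounds with values here, no step in this assay therefore sets a direction, and the expectation is for no change beyond the scatter, with a wide range on either side.

Compound 4 is estimated at 4000 nM, within 1200 nM to 13000 nM, which is expected to mean a 1.1-fold lower number from compound 2 to compound 4 (0.02 log units; within the scatter).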

Compound 4, solubility: 4200 nM
Compound 4: middle estimate off by 1.1-fold (0.02 log units), on the low side, within the range that was stated.
By their numbers in this assay, from the lowest: compounds 2, 3 and 4 (each within the scatter of the next); then compound 1.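

Going by these compounds alone, on a saturated chain carbon bound to an amine nitrogen, the one step available in this assay is no change at the digits printed from compound 2 to compound 4 (within the scatter) with the 4-cyanobenzyl group on the shared core held constant. Here furan-2-yl, with 5 heavy atoms and 0 hydrogen-bond donors, replaces 2-hydroxy-3-methoxyphenyl, with 9 heavy atoms and 1 hydrogen-bond donor, so this position tolerates that exchange without a step beyond the scatter, in this one pair only. No measurement at hand speaks to the mechanism behind this result.

From the compounds shown here alone, whether the same exchange would leave the number in place with 3-methoxyphenoxy on the core, as in compound 1, stays open. Also open, going by these compounds, is how this position responds to a group of another kind, such as a carboxylic acid or a piperidine.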